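A few compounds are considered here, and "the series" means these few. Any claim that something is new, unique, unknown or untested is made for them only; others in the source may bear on it.

In a functional assay on HL-60 cells (Homo sapiens) for cytotoxicity, read by MTT assay, with a stated time of 24 h (a lower number here means a stronger inhibitor, a higher number a weaker inhibitor), compound 1 `COC(=O)/C(=C\c1ccc(OC(=O)c2ccc(OC)cc2)cc1)Sc1ccnc2cc(Cl)ccc12` gives 9090 nM. Compound 2 `COC(=O)/C(=C\c1ccc(OC(=O)c2c(OC)cccc2OC)cc1)Sc1ccnc2cc(Cl)ccc12` gives 37200 nM in this assay, and compound 3 `COC(=O)/C(=C\c1ccc(OC(=O)c2ccc(OC)cc2OC)cc1)Sc1ccnc2cc(Cl)ccc12` gives 7640 nM. Compound 3 therefore has the lowest number of the three, but its distance from compound 1 is a 1.2-fold lower number from compound 1 to compound 3 (0.08 log units; within the scatter), which lies within the scatter, so these two cannot be ranked against each other; only compound 2 stands apart, at a 4.9-fold lower number from compound 2 to compound 3 (0.69 log units; beyond the scatter).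

Compound 4 `COC(=O)/C(=C\c1ccc(OC(=O)c2cc(OC)c(OC)c(OC)c2)cc1)Sc1ccnc2cc(Cl)ccc12` differs from compound 3 in one place: 3,4,5-trimethoxyphenyl in place of 2,4-dimethoxyphenyl on a carbonyl carbon. The measured steps show that rearranging methoxy groups on this aryl ester matters modestly: the step of a 4.1-fold higher number from compound 1 to compound 2 (0.61 log units; beyond the scatter) raised the number, and the step of a 4.9-fold lower number from compound 2 to compound 3 (0.69 log units; beyond the scatter) lowered it again, while the step of a 1.2-fold lower number from compound 1 to compound 3 (0.08 log units; within the scatter) stayed within the scatter. For the measured compounds named here, no measured pair covers a 3,4,5-trimethoxyphenyl, so the direction for compound 4 is uncertain; a move of about the size seen between compound 1 and compound 2, in either direction, or no move beyond the scatter, is plausible. The expected step from compound 3 is a 1.2-fold higher number from compound 3 to compound 4 (0.07 log units; within the scatter), and compound 4 is estimated at 9000 nM in this assay, with a range from 3000 nM to 27000 nM.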

Compound 4, half-maximal inhibitory concentration: 4240 nM
Compound 4: the middle estimate sits 2.1-fold (0.33 log units) above what was measured; the range from low to high includes it.
By their numbers in this assay, from the lowest: compounds 4, 3 and 1 (each within the scatter of the next, the first and the last beyond it); then compound 2.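

Replacing 2,4-dimethoxyphenyl with 3,4,5-trimethoxyphenyl on this carbonyl carbon gives a 1.8-fold lower number from compound 3 to compound 4 (0.26 log units; within the scatter) in this assay, so the two esters cannot be ranked against each other and the larger aryl group brings no measurable loss. The same group does separate from the 4-methoxyphenyl ester, with a 2.1-fold lower number from compound 1 to compound 4 (0.33 log units; beyond the scatter), a small step but the first among these compounds to fall beyond the scatter in the direction of a lower number from compound 1. The step from the 2,6-dimethoxyphenyl ester, an 8.8-fold lower number from compound 2 to compound 4 (0.94 log units; beyond the scatter), is the largest in the set, and compound 2 is now well separated from all three other compounds, which shows that adding methoxy groups to this aryl ring does not by itself raise the number, while the 2,6-dimethoxyphenyl arrangement remains the one clear exception; nothing available explains these differences.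

Every aryl group shown carries only methoxy groups, so the effect of a hydroxyl group, an amine or a chlorine on this ring remains open. Also open, on these data alone, is how a carboxylic acid in place of the methyl ester on the shared core would behave.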